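From 4-Bromophenyl to a Pyridin-2-yl Carbamoyl Chain

This account rests on a few compounds, and the source may have more. Where it says the series, first, only, none or still open, it means among the compounds named here.

Compound 1 `CN(CCNCc1cn(-c2ccccc2)nn1)CCNc1ccnc2cc(Cl)ccc12`: 25000 nM
Compound 2 `CN(CCNCc1cn(-c2ccc(Cl)cc2)nn1)CCNc1ccnc2cc(Cl)ccc12`: 14000 nM
Compound 3 `CN(CCNCc1cn(-c2ccc(Br)cc2)nn1)CCNc1ccnc2cc(Cl)ccc12`: 15000 nM

In a functional assay on NCI-H460 cells (Homo sapiens) for antiproliferative activity, read by sulforhodamine B assay, with a stated time of 72 h (on this read-out lower numbers stand for stronger inhibition and higher numbers for weaker inhibition), compound 3 gives 15000 nM, which places it second highest of the three numbers; its nearest neighbour is compound 2, and the step of a 1.1-fold higher number from compound 2 to compound 3 (0.03 log units; within the scatter), while the step of a 1.7-fold lower number from compound 1 to compound 3 (0.22 log units; within the scatter) is also within the scatter. Compound 4 `CN(CCNCc1cn(CCC(=O)Nc2ccccn2)nn1)CCNc1ccnc2cc(Cl)ccc12` differs from compound 3 as follows: 2-((pyridin-2-yl)carbamoyl)ethyl in place of 4-bromophenyl on an aromatic nitrogen. Within the data shown here, none of the measured steps replaces the whole aromatic group on that ring nitrogen; the steps of a 1.8-fold lower number from compound 1 to compound 2 (0.25 log units; within the scatter) and a 1.7-fold lower number from compound 1 to compound 3 (0.22 log units; within the scatter) only alter a substituent on it, and all three stay within the scatter. This suggests that changes at this position have so far moved the numbers little, but the present change is larger than any measured one, so the expectation carries wide uncertainty. Compound 4 is therefore expected to land near the measured range, with a step of a 1.2-fold higher number from compound 3 to compound 4 (0.08 log units; within the scatter). The estimated value for compound 4 is 18000 nM, with a range from 6000 nM to 50000 nM.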

Compound 4, half-maximal inhibitory concentration: > 200000 nM
Compound 4 ended at the assay's limit (the forecaster's own chance of this, stated with the estimate: 15%); middle value at least 11-fold (1.04 log units) away from the limit.
By their numbers in this assay, from the lowest: compounds 2, 3 and 1 (each within the scatter of the next). At a limit, above all of these: compound 4.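

In this assay compound 4 stands at a limit of the assay, not at a number: the limit of > 200000 nM in this assay, at which 1 of the 4 values shown sits. Putting 2-((pyridin-2-yl)carbamoyl)ethyl on the aromatic nitrogen in place of the aromatic ring gives an at least 13-fold higher number from compound 3 to compound 4 (1.12 log units; beyond the scatter), an at least 14-fold higher number from compound 2 to compound 4 (1.15 log units; beyond the scatter) and an at least 8.0-fold higher number from compound 1 to compound 4 (0.90 log units; beyond the scatter). Chloro or bromo on the phenyl ring left the numbers within the scatter of each other, whereas exchanging the whole group moves them beyond it, so this position is far from indifferent to what it carries.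

The compounds shown leave open which part of the new group goes with the weaker inhibition: the ethyl chain, the carbonyl and amide hydrogen, or the loss of the directly attached phenyl ring. A pyridin-2-yl ring set directly on that nitrogen, or a plain 3-phenylpropyl chain, would begin to separate these parts.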